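Benzamide in Place of the Aryl Urea in a Pyrazole Series

The source may hold more compounds than are shown below. What is called first, only, known or untested is meant among the compounds shown, and "the series" means these compounds.

Compound 2 `COc1cc(-c2nn(-c3cccc(NC(=O)Nc4ccc(Cl)c(C(F)(F)F)c4)c3)cc2-c2ccncc2)ccc1Cl` gives 499 nM in a functional assay on HOP-92 cells (Homo sapiens) for inhibition, read by sulforhodamine B assay, with a stated time of 48 h; a higher number here means a weaker inhibitor of growth, a lower number a stronger inhibitor of growth. Among the two compounds measured so far it carries the lowest number; its nearest neighbour is compound 1 `COc1cc(-c2nn(-c3cccc(NC(=O)Nc4cccc(C(F)(F)F)c4)c3)cc2-c2ccncc2)ccc1Cl`, which gives 557 nM in this assay, and the step of a 1.1-fold lower number from compound 1 to compound 2 (0.05 log units; within the scatter) lies within the usual scatter. Compound 3 `COc1cc(-c2nn(-c3cccc(NC(=O)c4ccccc4)c3)cc2-c2ccncc2)ccc1Cl` has not yet been measured. It differs from compound 2 in one place: phenyl in place of (4-chloro-3-(trifluoromethyl)phenyl)amino on a carbonyl carbon. Among the measured compounds shown here, the only measured step, that from compound 1 to compound 2, touches the same aryl group that leaves here, but it adds a single chloro and is within the scatter, so it says little about removing the whole (4-chloro-3-(trifluoromethyl)phenyl)amino together with its hydrogen-bond donor. The change is large in size and untested in this series, so the expectation for compound 3 in this assay rests on the step alone and is given wide bounds. Compound 3 is expected to give 2000 nM, with a range from 500 nM to 8000 nM, which corresponds to an estimated step of a 4.0-fold higher number from compound 2 to compound 3 (0.60 log units; beyond the scatter).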

Compound 3, concentration for 50% growth inhibition: 324 nM
Compound 3: the middle estimate sits 6.2-fold (0.79 log units) above what was measured; measured number below the stated range.
By their numbers in this assay, from the lowest: compounds 3, 2 and 1 (each within the scatter of the next).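

In this assay, the phenyl amide stands level with both aryl ureas. Putting phenyl in place of (4-chloro-3-(trifluoromethyl)phenyl)amino on the carbonyl carbon gives a 1.5-fold lower number from compound 2 to compound 3 (0.19 log units; within the scatter), and putting it in place of (3-(trifluoromethyl)phenyl)amino gives a 1.7-fold lower number from compound 1 to compound 3 (0.24 log units; within the scatter). The earlier compounds showed only that adding a chloro left the number within the scatter, whereas these steps show that this position accepts the loss of the whole substituted arylamino group, with its hydrogen-bond donor, and still gives a number within the scatter of both ureas; no evidence at hand bears on the reason for this.

Still open, going by these compounds, is whether the phenyl itself matters at this position, or whether a methyl, a morpholine or a carboxylic acid on the carbonyl carbon would move the number beyond the scatter. Also open, on these data alone, is whether a chloro or trifluoromethyl on this phenyl would make any difference.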